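The source may report more compounds than this note shows. Statements on the series, on what has been measured and on what is new or still open speak of the compounds shown alone.

Working notes on the series in a functional assay on MCF7 cells (Homo sapiens) for inhibition, read by MTT assay, with a stated time of 72 h; on this read-out higher numbers stand for weaker inhibition and lower numbers for stronger inhibition.

Of the compounds shown here, three carry numbers so far. Compound 1 `Fc1ccccc1Cn1cc(CSC(=S)N2CCNCC2)nn1` gives 33200 nM; compound 2 `CC(C)(C)OC(=O)N1CCN(C(=S)SCc2cn(-c3ccccc3F)nn2)CC1` gives 89600 nM; compound 3 `O=C(OCc1ccccc1)N1CCN(C(=S)SCc2cn(Cc3ccc(Cl)c(Cl)c3)nn2)CC1` gives 10600 nM. Compound 1 thus stands second highest of the three, with compound 2 above it and compound 3 below it, both gaps beyond the scatter. No pair among these three differs in a single place, so no step can be read off directly.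

Compound 4 `S=C(SCc1cn(Cc2ccccc2Cl)nn1)N1CCNCC1` is unmeasured. It differs from compound 1 in one place: chloro in place of fluoro on an aromatic carbon. A single halogen exchange on the ring, with the rest of the molecule held constant, gives no lead from the measured pairs, since compound 2 and compound 3 each change several features at once.

The step from compound 1 to compound 4 is expected to be small, at a 1.3-fold lower number from compound 1 to compound 4 (0.12 log units; within the scatter), likely not beyond the scatter. Compound 4 is therefore expected to give about 25000 nM, with a range of 10000 nM to 60000 nM.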

Compound 4, half-maximal inhibitory concentration: 38900 nM
Compound 4: middle estimate off by 1.6-fold (0.19 log units), on the low side, and the stated range covers the measured number.
By their numbers in this assay, from the lowest: compound 3; then compounds 1 and 4 (each within the scatter of the next); then compound 2.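

In this assay, the series now has its first direct step at a single place, the aromatic carbon ortho to a large group: chloro in place of fluoro gives a 1.2-fold higher number from compound 1 to compound 4 (0.07 log units; within the scatter). With the rest of the molecule held constant, the change from 2-fluorophenyl to 2-chlorophenyl therefore leaves no difference that this read-out can separate, so these two halogens cannot be told apart here. No measurement at hand bears on why this exchange reads as it does.

Still open, as far as these compounds go, is whether this position stays equally flat with a group other than a halogen, such as methoxy, nitrile or a bare hydrogen. Also open, from the compounds shown here alone, is whether the same exchange would read the same way on a core with a tert-butoxycarbonyl group in place of the free ring amine.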